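Nitro to methoxy: expected tolerance of compound 4

The source may hold more compounds than are shown below. What is called first, only, known or untested is meant among the compounds shown, and "the series" means these compounds.

Compound 1 `CC1=C(C(=O)Nc2ccccc2Cl)C(c2cccc(Br)c2)NC(=O)N1` gives > 100000 nM in an ADME assay on Vero cells (Chlorocebus sabaeus) for cytotoxicity, read by XTT assay, with a stated time of 72 h (a lower number here means that less compound is tolerated, a higher number that more compound is tolerated), which is a limit of the assay.
Compound 2 `CC1=C(C(=O)Nc2ccccc2Cl)C(c2ccc(Br)cc2)NC(=O)N1` gives > 100000 nM, again a limit of the assay.
Compound 3 `CC1=C(C(=O)Nc2ccccc2Cl)C(c2ccc([N+](=O)[O-])cc2)NC(=O)N1` is reported as "non-toxic" (no number reported).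

Compound 3 thus has no single number in this assay; the two other values shown sit at the limit of > 100000 nM in this assay, at which 2 of the 3 values shown sit. The change to compound 4 `COc1ccc(C2NC(=O)NC(C)=C2C(=O)Nc2ccccc2Cl)cc1` is methoxy in place of nitro on an aromatic carbon. Among the measured compounds shown here, the only step between measured compounds, a step that the two limits leave unreadable from compound 1 to compound 2, concerns a different position, and its size cannot be read. For the measured compounds named here, no measured step therefore bears on the change from compound 3 to compound 4, and no shift beyond the scatter is expected in this assay. Compound 4 is expected to sit at the same limit. For compound 4 the estimate in this assay is 100000 nM, within 50000 nM to 200000 nM.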

Compound 4, half-maximal cytotoxic concentration: > 100000 nM
Compound 4: no number, only a limit (the forecaster's own chance of this, stated with the estimate: 85%); the middle value lies on the limit itself.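

The steps from compound 1 and from compound 2 to compound 4 cannot be read in this assay. The compounds shown leave open at what concentration any of them harms the cells: the limit of > 100000 nM in this assay, at which 3 of the 4 values shown sit.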